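Bromo for Chloro on Two Related Cores

The compounds below may be only part of what the source reports. "The series", "measured", "known", "first", "only" and "open" are said of these compounds alone.

Compound 1, `NC(=S)N/N=C1/C(=O)N(CN2CCN(c3ccnc4cc(Cl)ccc34)CC2)c2cccc(Cl)c21`: 20700 nM
Compound 2, `NC(=S)N/N=C1/C(=O)N(CN2CCN(c3ccnc4cc(Cl)ccc34)CC2)c2cccc(Br)c21`: 46400 nM
Compound 3, `NC(=S)N/N=C1/C(=O)N(CN2CCN(c3ccnc4cc(C(F)(F)F)ccc34)CC2)c2cc(Cl)ccc21`: 20100 nM

These three compounds were examined in an ADME assay on 184B5 cells (Homo sapiens) for cytotoxicity, read by sulforhodamine B assay, with a stated time of 48 h; on this read-out higher numbers stand for weaker inhibition of growth and lower numbers for stronger inhibition of growth. Compound 1 and compound 2 share one core and differ by bromo in place of chloro on an aromatic carbon; that change gave a 2.2-fold higher number from compound 1 to compound 2 (0.35 log units; beyond the scatter). Compound 3 carries a different core, and the difference between the two cores is not broken down here. Compound 3 and compound 1 lie within the scatter of each other, while compound 2 shows a higher number than compound 3.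

Compound 4, `NC(=S)N/N=C1/C(=O)N(CN2CCN(c3ccnc4cc(C(F)(F)F)ccc34)CC2)c2cc(Br)ccc21`, has not yet been measured. It differs from compound 3 by bromo in place of chloro on an aromatic carbon, the same kind of change as that seen between compound 1 and compound 2, though the place is not identical: in compound 1 the chloro is ortho to a fused ring and meta to a fused ring, whereas in compound 3 it is meta to a fused ring and para to a fused ring. In this assay, going by the values given here, a step of about a 2.0-fold higher number from compound 3 to compound 4 (0.30 log units; within the scatter) is expected from compound 3 to compound 4, resting on the single comparable step a 2.2-fold higher number from compound 1 to compound 2 (0.35 log units; beyond the scatter). On this basis compound 4 is estimated at 40000 nM, with a likely range from 20000 nM to 80000 nM.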

Compound 4, concentration for 50% growth inhibition: 21400 nM
Estimate against measurement, compound 4: 1.9-fold (0.27 log units) above, and the stated range covers the measured number.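

In this assay, bromo in place of chloro on an aromatic carbon gave a 1.1-fold higher number from compound 3 to compound 4 (0.03 log units; within the scatter), a step that stays within the scatter. Set beside the earlier step on the other core, the two do not separate: the same change on two cores in this assay, a 2.2-fold higher number (0.35 log units; beyond the scatter) from compound 1 to compound 2 and a 1.1-fold higher number (0.03 log units; within the scatter) from compound 3 to compound 4, 2.1-fold (0.32 log units) apart, within the scatter of two such steps. Going by these compounds alone, this shows that the change can be carried between these two cores without a difference that these data can resolve, but it does not show that its size is the same on both, for each core offers only one step, the halogen sits in a different place on each, and one of the two steps lies within the scatter while the other lies beyond it.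

The compounds shown leave open how a fluoro or a methoxy group in the same place would compare with chloro and bromo on either core. They also leave open how much of the difference between the cores belongs to trifluoromethyl and how much to the place of the halogen.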